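The source may hold more compounds than are shown below. What is called first, only, known or untested is meant among the compounds shown, and "the series" means these compounds.

Compound 1 `CCc1cc(N)c2cc(NC(=O)/C=C/c3ccc(C(F)(F)F)cc3)ccc2n1` is the reference point of this small set. In an assay on isolated protein for displacement of a labelled ligand from melanin-concentrating hormone receptor 1 (Homo sapiens) (a lower number here means a stronger inhibitor, a higher number a weaker inhibitor), compound 1 gives 1.2 nM, the lower of the two numbers in hand. Compound 3 `CCCc1cc(N)c2cc(NC(=O)/C=C/c3ccc(I)cc3)ccc2n1` carries a propyl chain and an iodine where compound 1 carries an ethyl and a trifluoromethyl group; in this assay compound 3 gives 2.3 nM. The gap between compound 3 and compound 1 lies within the scatter, so the two cannot be ranked. Compound 2 `CCCc1cc(N2CCCCC2)c2cc(NC(=O)/C=C/c3ccc(C(F)(F)F)cc3)ccc2n1`, in which the amino group of the shared core is replaced, gives only a limit in this assay, > 4000 nM, and no number (the limit of > 4000 nM in this assay, at which 1 of the 3 values shown sits). Among the measured compounds shown here, no two of these three compounds differ in a single place, so no measured step is available.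

Compound 4 `Nc1cc(C2CCCC2)nc2ccc(NC(=O)/C=C/c3ccc(C(F)(F)F)cc3)cc12` has not yet been measured. It differs from compound 1 by cyclopentyl in place of ethyl on an aromatic carbon. Both keep the amino group and the trifluoromethyl group, and compound 3 shows that a propyl in place of ethyl, together with the change of halogen, leaves the number within the scatter of compound 1. For the measured compounds named here, with no measured step to point to, the expected change in this assay is modest and may go in either direction. Compound 4 is therefore estimated at 3 nM, within 0.8 nM to 15 nM. The expected step is a 2.5-fold higher number from compound 1 to compound 4 (0.40 log units; beyond the scatter).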

Compound 4, half-maximal inhibitory concentration: 0.8 nM
Compound 4: middle estimate off by 3.8-fold (0.57 log units), on the high side, within the range that was stated.
By their numbers in this assay, from the lowest: compounds 4, 1 and 3 (each within the scatter of the next, the first and the last beyond it). At a limit, above all of these: compound 2.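

Setting cyclopentyl in place of ethyl on the aromatic carbon next to the ring nitrogen gives a 1.5-fold lower number from compound 1 to compound 4 (0.18 log units; within the scatter) in this assay. Among the compounds shown here, this is the first measured step in the set that changes this position alone, and it shows that a five-membered non-aromatic ring of carbon only, with 5 heavy atoms in place of 2, can sit there with the number staying within the scatter of compound 1, so compound 4 and compound 1 cannot be ranked. Nothing in hand accounts for the size of this step.

The compounds shown leave open how far this position stays open to other groups: whether a phenyl ring, a longer chain such as hexyl, an amine or a carboxylic acid on the same aromatic carbon would keep the number in this range in this assay. For the compounds shown here, they also leave open what the amino group contributes on its own, as the one compound in which it is replaced, compound 2, also carries a propyl chain in place of ethyl, and no single step isolates that replacement.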